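The compounds below may be only part of what the source reports. "The series", "measured", "known", "first", "only" and "open" are said of these compounds alone.

Measured in a functional assay on PC-3 cells (Homo sapiens) for antiproliferative activity, read by MTT assay, with a stated time of 72 h; on this read-out higher numbers stand for weaker inhibition and lower numbers for stronger inhibition:
- Compound 1 `CCn1cc(C(CC)(CC)c2ccc(C#CC(O)(CC)CC)c(C)c2)cc1C(=O)NCCN(C)C`: 10100 nM
- Compound 2 `CCn1cc(C(CC)(CC)c2ccc(C#CC(O)(CC)CC)c(C)c2)cc1C(=O)OCCO`: 11400 nM
- Compound 3 `CCn1cc(C(CC)(CC)c2ccc(C#CC(O)(CC)CC)c(C)c2)cc1C(=O)NCCC(=O)O`: > 50000 nM, a limit

Compound 3 is the weakest of the three, and its value is only a limit of this assay. Compound 4 `CCn1cc(C(CC)(CC)c2ccc(C#CC(O)(CC)CC)c(C)c2)cc1C(=O)N[C@@H](C)CO` carries 1-(hydroxymethyl)ethyl in place of 2-carboxyethyl on an amide-type nitrogen. For the measured compounds named here, the steps that bear on this are an at least 4.9-fold higher number from compound 1 to compound 3 (0.69 log units; beyond the scatter) and an at least 4.3-fold higher number from compound 2 to compound 3 (0.64 log units; beyond the scatter). Both lie beyond the scatter, whereas a 1.1-fold higher number from compound 1 to compound 2 (0.05 log units; within the scatter) lies within it. Compound 4 loses the carboxy group and, like compound 2 at 11400 nM, has a hydroxy-ending chain, so it is expected to sit near that value. The expected change, towards stronger inhibition, is an at least 3.8-fold lower number from compound 3 to compound 4 (0.58 log units; beyond the scatter). The estimate for compound 4 is 13000 nM, with an expected range of 5000 nM to 35000 nM.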

Compound 4, half-maximal inhibitory concentration: 6050 nM
Estimate against measurement, compound 4: 2.1-fold (0.33 log units) above, within the range that was stated.
By their numbers in this assay, from the lowest: compounds 4, 1 and 2 (each within the scatter of the next). At a limit, above all of these: compound 3.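

On the amide-type nitrogen, in this assay, 1-(hydroxymethyl)ethyl in place of 2-carboxyethyl gives an at least 8.2-fold lower number from compound 3 to compound 4 (0.91 log units; beyond the scatter), which ties the loss in compound 3 to its 2-carboxyethyl chain and not to an amide at this place as such. Compound 3 remains a limit, so the true size of that step is unknown: the limit of > 50000 nM in this assay, at which 1 of the 4 values shown sits.

Against the other two, the new chain gives a 1.9-fold lower number from compound 2 to compound 4 (0.28 log units; within the scatter) and a 1.7-fold lower number from compound 1 to compound 4 (0.22 log units; within the scatter), both within the scatter, so these three side chains are not told apart.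

On these data alone, how a plain propyl chain, without the hydroxy group, or a primary amine would read on this nitrogen remains open.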